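Swapping the amide-bound aryl ring: bromine out, two fluorines in

The compounds below may be only part of what the source reports. "The series", "measured", "known", "first", "only" and "open" are said of these compounds alone.

Measured so far:
compound 1 `O=C(CN1CCN(c2nnc(Cc3ccncc3)c3ccccc23)CC1)Nc1cccc(Br)c1`: 1530 nM
compound 2 `O=C(CN1CCN(c2nnc(Cc3ccccc3)c3ccccc23)CC1)Nc1ccc(F)c(C(F)(F)F)c1`: 2480 nM
compound 3 `Cc1ccccc1NC(=O)CN1CCN(c2nnc(Cc3ccccc3)c3ccccc23)CC1`: "not active" (no number reported)

In a functional assay on A549 cells (Homo sapiens) for cytotoxicity, read by MTT assay, with a stated time of 72 h (on this read-out higher numbers stand for weaker inhibition and lower numbers for stronger inhibition), compound 1 gives 1530 nM, the lowest of the two reported numbers, though compound 2 at 2480 nM sits within the scatter, so neither can be called more potent. Compound 3 is reported as "not active" (no number reported).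

As far as these compounds go, compound 4 `O=C(CN1CCN(c2nnc(Cc3ccncc3)c3ccccc23)CC1)Nc1c(F)cccc1F` is untested. Its change from compound 1 is 2,6-difluorophenyl in place of 3-bromophenyl on an amide-type nitrogen. Going by the values given here, no measured pair isolates this swap, so the step is open. The expectation is a modest loss, with the step from a 2.6-fold higher number from compound 1 to compound 4 (0.42 log units; beyond the scatter) in this assay leaning toward weaker inhibition, partly since compound 3 gives "not active" (no number reported). Compound 4 is thus estimated at 4000 nM, within 1500 nM to 15000 nM.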

Compound 4, half-maximal inhibitory concentration: 54400 nM
Compound 4: the middle estimate sits 14-fold (1.13 log units) below what was measured; measured number outside the range, above it.
By their numbers in this assay, from the lowest: compounds 1 and 2 (each within the scatter of the next); then compound 4.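

In this assay, placing 2,6-difluorophenyl instead of 3-bromophenyl on the amide-type nitrogen gives a 36-fold higher number from compound 1 to compound 4 (1.55 log units; beyond the scatter), with the rest of the molecule unchanged. This first clean comparison at this position shows that the aryl ring on the amide can strongly affect the result, and that this swap is poorly tolerated. No available evidence explains the loss.

With both the substituent and its placement changing, their separate contributions remain unresolved. An unsubstituted phenyl, 3-chlorophenyl or 3-fluorophenyl ring on the same nitrogen could help separate them.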